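Ethyl oxime ether with a 3-methylpyridin-2-yl piperazine

The source may report more compounds than this note shows. Statements on the series, on what has been measured and on what is new or still open speak of the compounds shown alone.

Measured compounds:
compound 1, `Cc1ccccc1/C(CCN1CCN(c2ccccn2)CC1)=N\O`: 72%
compound 2, `CCO/N=C(\CCN1CCN(c2ccccc2C#N)CC1)c1ccccc1`: 82%

The series was characterised in a functional assay on HEK293 cells with D(4) dopamine receptor (Homo sapiens) as the target, read by FLIPR; on this read-out higher numbers stand for larger maximal responses and lower numbers for smaller maximal responses. Compound 1 gives 72% and compound 2 gives 82% in this assay. The two numbers sit within the scatter of each other, so the data do not show one compound reaching a larger maximal response than the other; compound 2 simply stands where these two measurements place it, with compound 1 as its nearest neighbour.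

The step now followed leads from compound 2 to compound 3, `CCO/N=C(\CCN1CCN(c2ncccc2C)CC1)c1ccccc1`, which has yet to be measured in this assay. The structural change is 3-methylpyridin-2-yl in place of 2-cyanophenyl on an amine nitrogen in a ring. Among the compounds with values here, no step between measured compounds changes the group on the amine nitrogen in a ring while leaving the rest unchanged, so no measured precedent for this exchange exists. Both measured compounds give large maximal responses in this assay, so the step from compound 2 to compound 3 is expected to be small, in either direction, and not beyond the scatter: a number 6 percentage points lower from compound 2 to compound 3 (within the scatter). Compound 3 is therefore estimated to give 76% in this assay, with a range from 58% to 94%.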

Compound 3, largest response reached (reported as efficacy), in percent of the reference or control that the assay uses: 49%
Compound 3: the middle estimate sits 27 percentage points above what was measured; measured number below the stated range.
By their numbers in this assay, from the lowest: compound 3; then compounds 1 and 2 (each within the scatter of the next).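

In this assay, putting 3-methylpyridin-2-yl in place of 2-cyanophenyl on an amine nitrogen in a ring gives a number 33 percentage points lower from compound 2 to compound 3 (beyond the scatter). Within the data shown here, this is the first direct reading of this position, as compound 1 and compound 2 differ in more than one place and offered no such step: with the rest of the structure held constant, the group on this nitrogen can change the maximal response by more than the usual scatter. The two groups have the same count of hydrogen-bond acceptors and no net charge, so neither of these counts distinguishes them, although the exchange does replace a ring of carbon only with one holding a hetero atom and removes the triple bond.

Nothing available explains the size or direction of this step. The exchange alters the ring and its substituent together, so the compounds shown leave open how much of the step belongs to each, a question that a 3-cyanopyridin-2-yl group on the same nitrogen, with the rest of compound 2 unchanged, would address.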